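A few compounds are considered here, and "the series" means these few. Any claim that something is new, unique, unknown or untested is made for them only; others in the source may bear on it.

Series notes. Compound 1 `O=S1(=O)N=C(NCC2CCCCC2)Nc2ncccc21`, compound 2 `C[C@H](NC1=NS(=O)(=O)c2cccnc2N1)C1CCCCC1` and compound 3 `CC(C)NC1=NS(=O)(=O)c2cc(Cl)cnc2N1` have been run in a functional assay (aorta) with Rattus norvegicus as the target; a lower number here means that less compound is needed, a higher number that more compound is needed for the effect; compound 4 `CCC(C)NC1=NS(=O)(=O)c2cc(Cl)cnc2N1` has not. In this assay compound 1 gives 45.7 uM, compound 2 gives 29.2 uM and compound 3 gives 14.6 uM. Between compound 1 and compound 2 the change is methyl in place of hydrogen on a saturated chain carbon bound to an amine nitrogen and a saturated ring carbon, and the step is a 1.6-fold lower number from compound 1 to compound 2 (0.19 log units; within the scatter). Compound 3 has the lowest of the three numbers, but its gap to compound 2 is within the scatter, so no order between those two is claimed; only the gap to compound 1 lies beyond it. The difference between the cores of compound 1 and compound 3 is not broken down here. From compound 3 to compound 4 the change is methyl in place of hydrogen on a saturated chain carbon, two bonds along the chain from an amine nitrogen. This is the same kind of change as from compound 1 to compound 2, though the place differs: there the carbon is bound to an amine nitrogen and a saturated ring carbon, here it sits two bonds along the chain from an amine nitrogen. For compound 4 a step like the earlier one is expected in this assay, a 1.3-fold lower number from compound 3 to compound 4 (0.12 log units; within the scatter), because the earlier step was a 1.6-fold lower number from compound 1 to compound 2 (0.19 log units; within the scatter) and within the scatter, while the different place and core allow nothing firmer. Compound 4 is thus expected to give about 11 uM, within 5 uM to 30 uM.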

Compound 4, concentration for half-maximal effect: 20 uM
Compound 4: the middle estimate sits 1.8-fold (0.26 log units) below what was measured, within the range that was stated.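

In this assay the methyl in place of hydrogen on the core of compound 3 gives a 1.4-fold higher number from compound 3 to compound 4 (0.14 log units; within the scatter), and set beside the earlier step on the core of compound 1, the two steps do not separate: the same change on two cores in this assay, a 1.6-fold lower number (0.19 log units; within the scatter) from compound 1 to compound 2 and a 1.4-fold higher number (0.14 log units; within the scatter) from compound 3 to compound 4, 2.1-fold (0.33 log units) apart, within the scatter of two such steps. Neither step lies beyond the scatter, so on these two pairs the change carries from one core to the other only as a step too small to read, with no direction assigned to it. This does not show that the methyl is without effect in the series, nor that the two places behave alike: there is one pair per core, and the carbon bound to an amine nitrogen and a saturated ring carbon is not the same place as the carbon two bonds along the chain from an amine nitrogen.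

Open, going by these compounds, is whether a longer chain such as n-pentyl in place of sec-butyl would give a step beyond the scatter on the core of compound 3. Also open, on these data alone, is how a phenyl ring or a carboxylic acid in that chain would read in this assay.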